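Bromine for Chlorine on the Aryl Ether of Compound 3

The source may report more compounds than this note shows. Statements on the series, on what has been measured and on what is new or still open speak of the compounds shown alone.

Measured so far:
Compound 1, `NC1=NC2(CCSCC2)N(OCCCOc2ccc(Cl)c(Cl)c2)C(N)=N1`, gives 88.4% in an assay on isolated protein for inhibition of Dihydrofolate reductase (Homo sapiens), read by spectrophotometry, using NADPH, with stated times of 5 s and 6 min, tested at 5 uM; a lower number here means a weaker effect, a higher number a stronger effect of the compound at the concentration tested.
Compound 2, `NC1=NC2(CCSCC2)N(OCCCOc2cccc(Cl)c2)C(N)=N1`, gives 88.3%.
Compound 3, `NC1=NC2(CCOCC2)N(OCCCOc2ccc(Cl)cc2)C(N)=N1`, is reported only as a limit, > 90%.

Among the measured compounds shown here, compound 3 therefore sits at the upper edge of what this assay reports: it is the one of the three values that stands at the limit of > 90% in this assay, at which 1 of the 3 values shown sits, a limit and not a number. Compound 4, `NC1=NC2(CCOCC2)N(OCCCOc2ccccc2Br)C(N)=N1`, has not been measured. It differs from compound 3 in one place: 2-bromophenyl in place of 4-chlorophenyl on an oxygen on a saturated carbon. A 2-bromophenyl thus enters where a 4-chlorophenyl leaves, on the oxygen of the saturated carbon at the end of the chain.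

For the measured compounds named here, only one measured step touches the aromatic ring of this ether, and it is a number 0.1 percentage points lower from compound 1 to compound 2 (within the scatter), a change of hydrogen for chloro on an aromatic carbon that left the read-out essentially unmoved. Nothing measured here separates chloro from bromo, or one ring position from another, so the expectation rests on that single step: no change beyond the scatter in this assay, in either direction. Compound 4 is accordingly expected to give about 88%, between 76% and 95%. The estimated step of a number at least 2 percentage points lower from compound 3 to compound 4 (that floor lies within the scatter) is expected to stay within the scatter.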

Compound 4, a percentage reported as inhibition, at one concentration (the size of the read-out at that concentration, not a potency): 83.8%
Estimate against measurement, compound 4: 4.2 percentage points above; the range from low to high includes it.
By their numbers in this assay, from the lowest: compounds 4, 2 and 1 (each within the scatter of the next). At a limit, above all of these: compound 3.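

In this assay, the exchange of 4-chlorophenyl for 2-bromophenyl on an oxygen on a saturated carbon gives a number at least 6.2 percentage points lower from compound 3 to compound 4 (that floor lies within the scatter). The entry for compound 3, > 90%, is a limit of the assay and not a number. Unlike the earlier step, which only removed a chloro group, this one changes both the halogen and its place on the ring, and compound 4 still gives a clear read-out of 83.8%. This change brings no loss that can be claimed beyond the scatter, although the full size of the step cannot be read from a floor set by a limit: the limit of > 90% in this assay, at which 1 of the 4 values shown sits.

The compounds shown include neither 2-chlorophenyl nor 4-bromophenyl, so the contribution of bromine for chlorine remains inseparable from that of the new ring position. They also leave open how this position would respond to a group other than a halogen, such as an amine or a carboxylic acid on the ring, or to a longer chain between the ring and the core.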